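Notes on one shared core with three side-group variants

A few compounds are considered here, and "the series" means these few. Any claim that something is new, unique, unknown or untested is made for them only; others in the source may bear on it.

Compound 1 `Cc1noc(C)c1COC1CC(=O)Nc2c1c(C)nn2-c1ncnc2nc[nH]c12` in a functional assay on HEK293 cells for agonist activity at G-protein coupled receptor 39 (Homo sapiens), read by scintillation proximity assay and inositol phosphate accumulation, with a stated time of 75 min, in the presence of a further agent that is not named here; on this read-out lower numbers stand for an effect already at smaller amounts and higher numbers for an effect only at larger amounts of compound: 5 nM.
Compound 2 `Cc1nn(-c2ncnc3nc[nH]c23)c2c1C(OCc1ccccc1F)CC(=O)N2` in this assay: 4 nM.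
Compound 3 `Cc1nn(-c2ncnc3nc[nH]c23)c2c1C(NC(=O)Cc1cccs1)CC(=O)N2` in this assay: 3 nM.

Compound 3 gives the lowest of the three numbers, yet a 1.7-fold lower number from compound 1 to compound 3 (0.22 log units; within the scatter) and a 1.3-fold lower number from compound 2 to compound 3 (0.12 log units; within the scatter) both lie within the scatter, so no order among the three compounds can be claimed. Compound 4 `Cc1nn(-c2ncnc3nc[nH]c23)c2c1C(OCc1ccc(F)cc1)CC(=O)N2` differs from compound 3 by (4-fluorobenzyl)oxy in place of (((thiophen-2-yl)methyl)carbonyl)amino on a saturated ring carbon. The step that bears most on this change is a 1.3-fold lower number from compound 2 to compound 3 (0.12 log units; within the scatter), which runs the reverse way between a (2-fluorobenzyl)oxy group and the same amino group; a 1.3-fold lower number from compound 1 to compound 2 (0.10 log units; within the scatter) likewise shows that exchanging one oxygen-linked side group for another alters little. No step beyond the scatter is therefore expected, a 1.3-fold higher number from compound 3 to compound 4 (0.12 log units; within the scatter). Compound 4 is estimated at 4 nM, with a range from 1.5 nM to 12 nM.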

Compound 4, half-maximal effective concentration: 1 nM
Estimate against measurement, compound 4: 4.0-fold (0.60 log units) above; measured number outside the range, below it.
By their numbers in this assay, from the lowest: compound 4; then compounds 3, 2 and 1 (each within the scatter of the next).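

With (4-fluorobenzyl)oxy on the saturated ring carbon, this position gives a step beyond the scatter against the thiophene amide side group (a 3.0-fold lower number from compound 3 to compound 4 (0.48 log units; beyond the scatter)), although all earlier exchanges there stayed within it. Moving the fluorine from 2-fluorophenyl to 4-fluorophenyl is enough for a step of similar kind (a 4.0-fold lower number from compound 2 to compound 4 (0.60 log units; beyond the scatter)), and replacing 3,5-dimethyl-1,2-oxazol-4-yl gives the same direction (a 5.0-fold lower number from compound 1 to compound 4 (0.70 log units; beyond the scatter)). No measurement at hand explains this gain.

Open, as far as these compounds go, is whether the fluorine itself is needed, which a plain benzyl group or a chlorine in its place would test. Also open, from the compounds shown here alone, is whether an amino link carrying the same 4-fluorobenzyl group would hold the value.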